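The compounds below may be only part of what the source reports. "The series", "measured", "known", "first", "only" and "open" are said of these compounds alone.

Values measured in a functional assay on SH-SY5Y cells (Homo sapiens) for cytotoxicity, read by MTT assay, with a stated time of 72 h; a lower number here means a stronger inhibitor, a higher number a weaker inhibitor:
- Compound 1 `O=C1c2c[n+]([O-])c3ccccc3c2C(=O)c2c1c1ccccc1n2CCCCn1ccnc1`: 130 nM
- Compound 2 `O=C1c2c[n+]([O-])c3ccccc3c2C(=O)c2c1c1ccccc1n2CCCCN1CCNCC1`: 1240 nM
- Compound 3 `CN1CCN(CCCCCCn2c3c(c4ccccc42)C(=O)c2c[n+]([O-])c4ccccc4c2C3=O)CC1`: 920 nM

In this assay, compound 3 cannot be separated from its nearest neighbour, as the measured step shows: a 1.3-fold lower number from compound 2 to compound 3 (0.13 log units; within the scatter). It stands clearly apart from the furthest of the three: a 7.1-fold higher number from compound 1 to compound 3 (0.85 log units; beyond the scatter).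

The next compound to be considered is compound 4 `O=C1c2c[n+]([O-])c3ccccc3c2C(=O)c2c1c1ccccc1n2CCCN1CCC(O)CC1`, which differs from compound 3 in one place: 4-hydroxypiperidin-1-yl in place of 3-(4-methylpiperazin-1-yl)propyl on a saturated chain carbon, three bonds along the chain from an aromatic nitrogen. The 3-(4-methylpiperazin-1-yl)propyl leaves, and 4-hydroxypiperidin-1-yl enters on a saturated chain carbon, three bonds along the chain from an aromatic nitrogen.

Going by the values given here, no measured step makes this exact exchange. Among the compounds with values here, the closest precedent swaps one saturated ring group for another, and it stayed small: a 1.3-fold lower number from compound 2 to compound 3 (0.13 log units; within the scatter). The two larger steps both start from the 1H-imidazol-1-yl of compound 1: a 9.5-fold higher number from compound 1 to compound 2 (0.98 log units; beyond the scatter) and a 7.1-fold higher number from compound 1 to compound 3 (0.85 log units; beyond the scatter). Compound 4 carries no such group, so these two bear on it only weakly. The data therefore give no reason to expect a shift beyond the scatter, though the untested hydroxyl-bearing ring leaves real uncertainty.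

The expected step is a 1.2-fold lower number from compound 3 to compound 4 (0.06 log units; within the scatter). For compound 4 the estimated value is 800 nM, with an expected range from 300 nM to 2100 nM.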

Compound 4, half-maximal inhibitory concentration: 130 nM
Estimate against measurement, compound 4: 6.2-fold (0.79 log units) above; measured number outside the range, below it.
By their numbers in this assay, from the lowest: compounds 1 and 4 (each within the scatter of the next); then compounds 3 and 2 (each within the scatter of the next).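

In this assay, replacing the 3-(4-methylpiperazin-1-yl)propyl with 4-hydroxypiperidin-1-yl at this place gave a 7.1-fold lower number from compound 3 to compound 4 (0.85 log units; beyond the scatter), and replacing the (piperazin-1-yl)methyl gave a 9.5-fold lower number from compound 2 to compound 4 (0.98 log units; beyond the scatter), so among these compounds a saturated ring on the chain does not in itself go with the higher numbers of the two piperazine compounds. Set against the (1H-imidazol-1-yl)methyl, the same group gave no change at the digits printed from compound 1 to compound 4 (within the scatter), which means that compound 1 no longer stands alone at the low end of the series and that an imidazole is not needed at this place for a number of that size. Nothing measured here accounts for the difference between the 4-hydroxypiperidin-1-yl and the piperazine groups.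

The compounds shown do not separate the contribution of the hydroxyl from that of the piperidine ring, a question that an unsubstituted piperidin-1-yl or a morpholin-4-yl on the same chain would address. They also leave open how the 4-hydroxypiperidin-1-yl would fare on a longer chain, such as the butyl chain that links the ring in compound 2.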